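Hydroxymethyl on the Aryl Ether of Compound 1

The source may report more compounds than this note shows. Statements on the series, on what has been measured and on what is new or still open speak of the compounds shown alone.

Compound 1 `CCN(Cc1cccs1)C(=O)COc1ccccc1` is measured in an assay on HEK293 cells for agonist activity at transient receptor potential cation channel subfamily M member 8 (Homo sapiens), read by fluorescence and calcium flux, with a stated time of 15 min (a higher number here means that more compound is needed for the effect, a lower number that less compound is needed), and gives 1400 nM. Among the three measured compounds it stands second highest: compound 2 `CCN(Cc1cccs1)C(=O)COc1cccc(C)c1` gives 97 nM, and compound 3 `Cc1ccc(OCC(=O)N(Cc2cccs2)c2cnn(C)c2)cc1` gives 63000 nM. For the measured compounds named here, the only single-place step among them runs a 14-fold lower number from compound 1 to compound 2 (1.16 log units; beyond the scatter), a methyl in place of hydrogen on an aromatic carbon. Compound 3 carries a different substituent on the amide nitrogen as well as a methyl on the ring, so its number and that of compound 1 are simply two values, without a step between them.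

Compound 4 `CCN(Cc1cccs1)C(=O)COc1ccc(CO)cc1` differs from compound 1 by hydroxymethyl in place of hydrogen on an aromatic carbon. Going by the values given here, the step from compound 1 to compound 2 shows that a small group on this ring can move this assay strongly, but it concerns a methyl at a different place, and no measured compound carries a hydroxymethyl anywhere. The expectation for compound 4 is therefore uncertain, and the estimated step is a 1.1-fold higher number from compound 1 to compound 4 (0.03 log units; within the scatter). Compound 4 is estimated at 1500 nM, within 300 nM to 8000 nM.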

Compound 4, half-maximal effective concentration: 21900 nM
Compound 4: the middle estimate sits 15-fold (1.16 log units) below what was measured, and the stated range ends below it.
By their numbers in this assay, from the lowest: compound 2; then compound 1; then compound 4; then compound 3.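

In this assay, placing hydroxymethyl on the aromatic carbon para to a large group gives a 16-fold higher number from compound 1 to compound 4 (1.19 log units; beyond the scatter), so a single substituent on this ring can raise the number as well as lower it. The earlier single-place step on this ring, a 14-fold lower number from compound 1 to compound 2 (1.16 log units; beyond the scatter), ran the opposite way, with a methyl at a different place. Nothing at hand gives a measured explanation for this rise.

Compound 2 and compound 4 differ in both the group and its place, so the compounds shown do not separate the effect of one from the other. Going by these compounds, it remains open whether a methoxy group, an aminomethyl group or a carboxylic acid at the same place would raise the number as hydroxymethyl does, and how hydroxymethyl would behave at the place of the methyl in compound 2.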